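Propyl in Place of 1,1-Dimethylpropyl, Made a Second Time

The source may hold more compounds than are shown below. What is called first, only, known or untested is meant among the compounds shown, and "the series" means these compounds.

Three compounds have been measured in a functional assay (aorta) with Rattus norvegicus as the target; a lower number here means a stronger inhibitor, a higher number a weaker inhibitor:
compound 1, `CCC(C)(C)/N=C(\NC#N)Nc1cc(C(F)(F)F)cc(C(F)(F)F)c1`, gives 900 nM;
compound 2, `CCC/N=C(\NC#N)Nc1cc(C(F)(F)F)cc(C(F)(F)F)c1`, gives 12400 nM;
compound 3, `CCC(C)(C)/N=C(\NC#N)Nc1cc(Cl)cc(Cl)c1`, gives 300 nM.

Compound 1 and compound 2 differ by one change, (propyl in place of 1,1-dimethylpropyl on a double-bonded nitrogen), and this change brought a 14-fold higher number from compound 1 to compound 2 (1.14 log units; beyond the scatter). Compound 3 carries a different core from compound 1; how the two cores differ is not broken down here. What the measured values show is that compound 3 gives a lower number than compound 1, and a much lower one than compound 2.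

Compound 4, `CCC/N=C(\NC#N)Nc1cc(Cl)cc(Cl)c1`, is not yet measured. It stands to compound 3 as compound 2 stands to compound 1: the difference is propyl in place of 1,1-dimethylpropyl on a double-bonded nitrogen, and the place is described in the same words in both pairs, so it is the same change.

In this assay, among the compounds with values here, the expected step for compound 4 is a 13-fold higher number from compound 3 to compound 4 (1.12 log units; beyond the scatter), a weakening expected because a 14-fold higher number from compound 1 to compound 2 (1.14 log units; beyond the scatter) is the only measured example of this change. Compound 4 is therefore estimated at 4000 nM, with a likely range from 1500 nM to 12000 nM.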

Compound 4, half-maximal inhibitory concentration: 31000 nM
Compound 4: the middle estimate sits 7.8-fold (0.89 log units) below what was measured; measured number above the stated range.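

In this assay, replacing 1,1-dimethylpropyl with propyl on the core of compound 3 gives a 100-fold higher number from compound 3 to compound 4 (2.01 log units; beyond the scatter) and so weakens the inhibitor, as it did on the core of compound 1. The direction of the change therefore carries over from one core to the other, but its size does not: the same change on two cores in this assay, a 14-fold higher number (1.14 log units; beyond the scatter) from compound 1 to compound 2 and a 100-fold higher number (2.01 log units; beyond the scatter) from compound 3 to compound 4, 7.5-fold (0.88 log units) apart, beyond the scatter of two such steps

These two pairs do not explain why the loss is larger on the core of compound 3, and they give no rule for predicting its size on a third core.

As far as these compounds go, only two chains have been compared here, so it remains open how the number changes between them, for example whether a butyl chain or a cyclopentyl ring would stay closer to 1,1-dimethylpropyl or to propyl. From the compounds shown here alone, it is also open whether such a group would show the same larger loss on the core of compound 3 as propyl does.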